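The source may report more compounds than this note shows. Statements on the series, on what has been measured and on what is new or still open speak of the compounds shown alone.

Of the compounds shown here, three have so far been measured in a functional assay on HT-29 cells (Homo sapiens) for inhibition, read by sulforhodamine B assay, with a stated time of 48 h; a lower number here means a stronger inhibitor of growth, a higher number a weaker inhibitor of growth. Compound 1 `COc1cc(C)cc(-c2c(-c3ccnc(-c4ccc(C(C)=O)cc4)c3)cnn2CC#N)c1` gives 3210 nM, and compound 2 `COc1cc(C)cc(-c2nn(CC#N)cc2-c2ccc(-c3cccc(C(C)=O)c3)nc2)c1` gives 3280 nM. Compound 3 `Cc1cc(O)cc(-c2nn(CC#N)cc2-c2ccnc(-c3ccc(Oc4ccccc4)cc3)c2)c1` gives 1830 nM in this assay, the lowest of the three numbers, yet its gaps to compound 1 and to compound 2 both lie within the scatter, so nothing sets compound 3 apart from the other two.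

Compound 4 `Cc1cc(O)cc(-c2nn(CC#N)cc2-c2ccnc(-c3ccc(N(C)C)cc3)c2)c1` has not yet been measured in this assay. It differs from compound 3 in one place: dimethylamino in place of phenoxy on an aromatic carbon. For the measured compounds named here, no measured pair shows a change of this kind, so the size of the step in this assay cannot be read from the numbers at hand. Going by the values given here, since nothing among the measured compounds points in either direction, a step no larger than the scatter is expected. Compound 4 is therefore estimated to give about 2500 nM in this assay, between 800 nM and 8000 nM. The step from compound 3 to compound 4 is expected to be a 1.4-fold higher number from compound 3 to compound 4 (0.14 log units; within the scatter), a small one.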

Compound 4, concentration for 50% growth inhibition: 4650 nM
Estimate against measurement, compound 4: 1.9-fold (0.27 log units) below; the measured number falls inside the stated range.
By their numbers in this assay, from the lowest: compounds 3, 1, 2 and 4 (each within the scatter of the next, the first and the last beyond it).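

In this assay, for the compounds shown here, the exchange of phenoxy for dimethylamino on an aromatic carbon, para to a large group, gives a 2.5-fold higher number from compound 3 to compound 4 (0.41 log units; beyond the scatter) and so provides the only single-place comparison. It shows that the group at this position can move the number beyond the scatter, which the three earlier compounds could not show, and that the direction here is towards weaker growth inhibition. The change removes an aromatic ring while the counts of hydrogen-bond donors and acceptors stay the same, but no measurement at hand accounts for the step.

Still open, going by these compounds, is whether the step follows the loss of the ring or the arrival of the nitrogen. A methoxy group or a phenylamino group on this carbon would separate the two, and a carboxylic acid there would test a different kind of group.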